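A few compounds are considered here, and "the series" means these few. Any claim that something is new, unique, unknown or untested is made for them only; others in the source may bear on it.

Compound 1 `Cc1cc(C)c2c(c1C)OC(C)(COc1ccc(CC3SC(=O)NC3=O)cc1)CC2` is the starting point of this comparison. In a functional assay on MCF7 cells (Homo sapiens) for antiproliferative activity, read by luminescence, with a stated time of 24 h (on this read-out lower numbers stand for stronger inhibition and higher numbers for weaker inhibition), compound 1 gives 20000 nM, the highest number among the three measured compounds. Compound 3 `Cc1c(C)c2c(c(C)c1OC(=O)CCCCCCCNC(=O)OC(C)(C)C)CCC(C)(COc1ccc(/C=C3\SC(=O)NC3=O)cc1)O2` comes nearest, giving 13000 nM, which lies within the scatter of compound 1. Compound 2 `Cc1c(C)c2c(c(C)c1OC(=O)CCCCCCCN)CCC(C)(COc1ccc(/C=C3\SC(=O)NC3=O)cc1)O2` stands furthest away, giving 3200 nM, a number beyond the scatter from compound 1. Compounds 2 and 3 differ from compound 1 in more than one place, so their values show only where compound 1 stands.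

Compound 4 `Cc1c(C)c2c(c(C)c1OC(=O)OC(C)(C)C)CCC(C)(COc1ccc(CC3SC(=O)NC3=O)cc1)O2` is the unmeasured member. It differs from compound 1 by (tert-butoxycarbonyl)oxy in place of hydrogen on an aromatic carbon. Among the compounds with values here, the only measured step that touches the same group is a 4.1-fold higher number from compound 2 to compound 3 (0.61 log units; beyond the scatter), where the tert-butoxycarbonyl group was added on an amine nitrogen rather than on an aromatic carbon through an oxygen. Within the data shown here, that step went toward a higher number, and it is the sole guide here; its place is not the same as in compound 4, so it carries limited weight. A step of modest size toward a higher number, or none beyond the scatter, is therefore expected for compound 4, written as a 1.5-fold higher number from compound 1 to compound 4 (0.18 log units; within the scatter). In this assay compound 4 is estimated at 30000 nM, with a range from 10000 nM to 100000 nM.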

Compound 4, half-maximal inhibitory concentration: 11200 nM
Compound 4: middle estimate off by 2.7-fold (0.43 log units), on the high side, and the stated range covers the measured number.
By their numbers in this assay, from the lowest: compound 2; then compounds 4, 3 and 1 (each within the scatter of the next).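

In this assay, putting (tert-butoxycarbonyl)oxy on this aromatic carbon, ortho to two methyl groups, gives a 1.8-fold lower number from compound 1 to compound 4 (0.25 log units; within the scatter), so a group of 8 heavy atoms enters here without a shift beyond the scatter. Within the data shown here, this is the first direct reading at this position, as the earlier compounds differ from compound 1 in more than one place. The tert-butoxycarbonyl step on an amine nitrogen, a 4.1-fold higher number from compound 2 to compound 3 (0.61 log units; beyond the scatter), went beyond the scatter, so in these two pairs the result on the amine nitrogen does not repeat on this aromatic carbon, and no measurement shown explains this difference.

On these data alone, compound 2 carries an ester with a longer chain ending in an amine at the same aromatic carbon, but it differs from compound 4 in more than one place, so how much of its lower number belongs to that chain stays open. Also open, as far as these compounds go, is what a hydroxyl group, a methoxy group or that amine-ended ester would give at this position on the unchanged core of compound 1.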